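Selenium to Sulfur on the Core of Compound 1

The compounds below may be only part of what the source reports. "The series", "measured", "known", "first", "only" and "open" are said of these compounds alone.

Compound 1, `C[Se]/C(=N\C(=O)c1cc2ccccc2s1)NC(=O)c1cc2ccccc2s1`: 5070 nM
Compound 2, `C[Se]/C(=N\C(=O)c1cc(-c2ccccc2)nc2ccccc12)NC(=O)c1cc(-c2ccccc2)nc2ccccc12`: 490 nM

Of the compounds shown here, two have been tested in a functional assay on MCF7 cells (Homo sapiens) for cytotoxicity, read by MTT assay, with a stated time of 72 h; on this read-out lower numbers stand for stronger inhibition of growth and higher numbers for weaker inhibition of growth. Compound 1 gives 5070 nM, the higher of the two numbers, meaning the weaker inhibition of growth. Compound 2 gives 490 nM, and the gap between the two lies beyond the usual scatter. Within the data shown here, compound 2 carries a different core, so no pair of measured compounds differs in a single place, and no measured step shows how a small change moves the numbers.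

Compound 3, `CS/C(=N\C(=O)c1cc2ccccc2s1)NC(=O)c1cc2ccccc2s1`, differs from compound 1 in one place: a group of 2 heavy atoms (1 carbon, 1 sulfur; no ring) in place of a group of 2 heavy atoms (1 carbon, 1 selenium; no ring), on a carbon with a double bond to nitrogen. The measured compounds give no guide to this particular change. The step of a 2.4-fold higher number from compound 1 to compound 3 (0.37 log units; beyond the scatter) is expected to be a modest rise in the number, toward weaker inhibition, though it may well fall within the scatter. Compound 3 is therefore estimated at 12000 nM, with a range from 4000 nM to 40000 nM.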

Compound 3, concentration for 50% growth inhibition: 9510 nM
Estimate against measurement, compound 3: 1.3-fold (0.10 log units) above, and the stated range covers the measured number.
By their numbers in this assay, from the lowest: compound 2; then compounds 1 and 3 (each within the scatter of the next).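

In this assay, among these compounds, the methylsulfanyl group taking the place of the selenium-bearing group, on a carbon with a double bond to nitrogen, gives a 1.9-fold higher number from compound 1 to compound 3 (0.27 log units; within the scatter) and is the only single-place step available so far. That step lies within the scatter, so selenium and sulfur at this place cannot be told apart on this read-out, and compound 1 and compound 3 inhibit growth about equally. No supporting data are available to explain this result.

From the compounds shown here alone, whether selenium and sulfur also match on the core of compound 2 remains open. So does the effect of a longer chain on the sulfur, such as ethylsulfanyl, or of an amine at this same place.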